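A few compounds are considered here, and "the series" means these few. Any claim that something is new, unique, unknown or untested is made for them only; others in the source may bear on it.

Measured in a functional assay on MT4 cells (Homo sapiens) for cytotoxicity, read by MTT assay; a higher number here means that more compound is tolerated, a lower number that less compound is tolerated:
- Compound 1 `Cc1c(O)nc(S(=O)(=O)Cc2ccc([N+](=O)[O-])cc2)nc1Cc1c(Cl)cccc1Cl`: > 53000 nM, a limit
- Compound 2 `COc1ccc(CSc2nc(O)c(C)c(Cc3c(Cl)cccc3Cl)n2)cc1OC`: > 55000 nM, a limit
- Compound 3 `Cc1c(O)nc(SCc2ccc(C#N)cc2)nc1Cc1c(Cl)cccc1Cl`: > 60000 nM, a limit

None of these three results is a number, so the compounds cannot be ranked against one another. Compound 3 stands only at its limit of > 60000 nM.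

Compound 4 `Cc1c(O)nc(SCc2ccccc2)nc1Cc1c(Cl)cccc1Cl` has hydrogen in place of cyano on an aromatic carbon, para to a large group, turning 4-cyanobenzyl into benzyl: hydrogen in place of cyano on an aromatic carbon. Going by the values given here, no measured pair shows a single change of this kind. Nothing beyond the scatter is therefore expected in this assay, in either direction, and another limit is the likeliest result. The expected change is a step that the limit leaves unreadable from compound 3 to compound 4. Compound 4 is estimated at 64000 nM, with an expected range from 25000 nM to 100000 nM.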

Compound 4, half-maximal cytotoxic concentration: > 64000 nM
Compound 4 was reported as a limit (the forecaster's own chance of this, stated with the estimate: 75%); the middle value sits exactly at the limit.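

Going by these compounds alone, compound 3 and compound 4 are both reported only as limits, so no step between them can be read. The compounds shown leave open whether hydrogen in place of cyano changes the tolerated concentration at all.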